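This account rests on a few compounds, and the source may have more. Where it says the series, first, only, none or still open, it means among the compounds named here.

Measured so far:
compound 1, `ClCc1cccc(Cn2cnc3ncnc(Cl)c32)c1`, 39800 nM
compound 2, `ClCc1cccc(Cn2cnc3c(Cl)ncnc32)c1`, 6450 nM
compound 3, `ClCc1cccc(Cn2cnc3c(Cl)nc(Cl)nc32)c1`, 6310 nM

The three measured compounds were tested in a functional assay on MDA-MB-435 cells (Homo sapiens) for cytotoxicity, read by sulforhodamine B assay, with a stated time of 48 h; on this read-out higher numbers stand for lower toxicity in this test and lower numbers for higher toxicity in this test. Compound 1 gives 39800 nM, the highest of the three numbers, so it is the least toxic of the three in this assay; its steps to compound 2 and compound 3 are both beyond the scatter. Compound 2 and compound 3 share the same atoms as compound 1 but joined differently; how the core of compound 1 differs from the core of compound 2 is not broken down here.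

Compound 2 and compound 3 differ in one place: chloro in place of hydrogen on an aromatic carbon. This change gave a 1.0-fold lower number from compound 2 to compound 3 (0.01 log units; within the scatter), so the two compounds are not distinguishable in this assay.

Compound 4, `ClCc1cccc(Cn2cnc3nc(Cl)nc(Cl)c32)c1`, has not yet been measured. It relates to compound 1 as compound 3 relates to compound 2: chloro in place of hydrogen on an aromatic carbon. The two descriptions of the place are the same word for word, so this is the same change, made on the other core. Among the compounds with values here, since it produced no measurable step from compound 2 to compound 3, the expectation is that it also produces little from compound 1, and the estimated step is a 1.1-fold lower number from compound 1 to compound 4 (0.04 log units; within the scatter). Compound 4 is therefore expected to give about 36000 nM in this assay, estimated to lie between 15000 nM and 85000 nM. This rests on a single pair, compound 2 and compound 3, and the cores differ, so the estimate is uncertain.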

Compound 4, concentration lethal to 50% of the cells: 5240 nM
Estimate against measurement, compound 4: 6.9-fold (0.84 log units) above; measured number outside the range, below it.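

In this assay, putting chloro in place of hydrogen on an aromatic carbon, on a carbon between two ring nitrogen atoms, gave a 7.6-fold lower number from compound 1 to compound 4 (0.88 log units; beyond the scatter), so on the core of compound 1 this small change has a clear effect on the read-out. Within the data shown here, the earlier pair gave no such step, which shows that the size of this change did not carry from one core to the other here, and that a step seen on one core was a poor guide to the step on the other: the same change on two cores in this assay, a 1.0-fold lower number (0.01 log units; within the scatter) from compound 2 to compound 3 and a 7.6-fold lower number (0.88 log units; beyond the scatter) from compound 1 to compound 4, 7.4-fold (0.87 log units) apart, beyond the scatter of two such steps. This does not show why the two cores respond differently, and it rests on a single pair for each core in a single cell test, so it sets no general rule for the series.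

All the compounds shown carry either hydrogen or chloro at this place, so it remains open whether an amine, a methoxy group or a longer chain there would also give steps that differ from one core to the other. As far as these compounds go, it also remains open whether the same difference between the cores would appear with a change made elsewhere on the molecule, such as replacing the chloromethyl group with a hydroxymethyl group.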